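The source may hold more compounds than are shown below. What is called first, only, known or untested is meant among the compounds shown, and "the series" means these compounds.

Measured so far in an ADME assay on HEK293 cells (Homo sapiens) for cytotoxicity, read by resazurin assay, with a stated time of 48 h; on this read-out lower numbers stand for higher toxicity in this test and higher numbers for lower toxicity in this test:
compound 1 `Cc1ccc(S(=O)(=O)Nc2ccc(-c3nc4ccccc4o3)cc2)cc1` gives 88000 nM.
compound 3 `O=S(=O)(Nc1ccc2oc(-c3ccccc3)nc2c1)c1ccc(Cl)c(Cl)c1` gives 71000 nM.
compound 2 `O=S(=O)(Nc1ccc2oc(-c3ccccc3)nc2c1)c1ccc(F)c(C(F)(F)F)c1` gives a limit of the assay, > 100000 nM.

Compound 1 holds the higher of the two numbers in this assay, but its nearest neighbour is compound 3, whose number sits within the scatter of repeated measurements, so the two cannot be told apart. The value of compound 2 is a limit and not a number (the limit of > 100000 nM in this assay, at which 1 of the 3 values shown sits). For the measured compounds named here, no pair among the measured compounds differs in one place only, so no measured step is available.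

Compound 4 `O=S(=O)(Nc1ccc(-c2nc3ccccc3o2)cc1)c1ccc(Cl)cc1` is not yet measured. It differs from compound 1 in one place: chloro in place of methyl on an aromatic carbon. On the strength of the three numbers shown, all of which sit in the same weakly toxic region, the step from compound 1 to compound 4 is expected to stay within the scatter, a 1.1-fold lower number from compound 1 to compound 4 (0.04 log units; within the scatter), in no firm direction. Compound 4 is therefore estimated at 80000 nM in this assay, within a range from 40000 nM to 160000 nM.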

Compound 4, half-maximal cytotoxic concentration: > 100000 nM
Compound 4: only a limit was reported; the forecaster's own chance of this, stated with the estimate: 30%; at least 1.2-fold (0.09 log units) between middle value and limit.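

In this assay compound 4 gives > 100000 nM, which is a limit of the assay and not a number. Chloro in place of methyl on an aromatic carbon, para to a large group, is the first single change that can be read in this set: it gives an at least 1.1-fold higher number from compound 1 to compound 4 (0.05 log units; that floor lies within the scatter), so this change shows no sign of higher toxicity in this test, while its floor alone does not separate the two compounds. With compound 4 the limit is reached a second time among the compounds shown: the limit of > 100000 nM in this assay, at which 2 of the 4 values shown sit.

From the compounds shown here alone, how far the true value of compound 4 lies from that limit, and so the full size of the step, stays open. The compounds shown also leave open what an amine, a carboxylic acid or a longer chain at this same place would give in this assay.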